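This account rests on a few compounds, and the source may have more. Where it says the series, first, only, none or still open, it means among the compounds named here.

Measured compounds:
compound 1 `ClCc1ccccc1Cn1cnc2c(Cl)nc(Cl)nc21` — 1820 nM
compound 2 `ClCc1cccc(Cn2cnc3c(Cl)ncnc32)c1` — 20400 nM

In a functional assay on UACC-257 cells (Homo sapiens) for cytotoxicity, read by sulforhodamine B assay, with a stated time of 48 h (a lower number here means a stronger inhibitor of growth, a higher number a weaker inhibitor of growth), compound 1 gives the lowest of the two numbers; compound 2 gives a higher number, a gap beyond the scatter. Within the data shown here, the two compounds differ in more than one place, so their values show only that gap and no single step.

Compound 3 `Nc1nc(Cl)c2ncn(Cc3ccccc3CCl)c2n1` differs from compound 1 by amino in place of chloro on an aromatic carbon. Among the measured compounds shown here, no measured pair shows this change, so the size of the step in this assay is open; a modest weakening is expected, though within a range that also allows no change beyond the scatter. For compound 3 the estimate is 3000 nM, between 800 nM and 12000 nM, which means an expected step of a 1.6-fold higher number from compound 1 to compound 3 (0.22 log units; within the scatter).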

Compound 3, concentration for 50% growth inhibition: 13200 nM
Beside the measured number, compound 3's estimate is 4.4-fold (0.64 log units) below it, and the stated range ends below it.
By their numbers in this assay, from the lowest: compound 1; then compounds 3 and 2 (each within the scatter of the next).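

In this assay, the aromatic carbon between two ring nitrogen atoms now has a single change that can be read: amino in place of chloro gives a 7.3-fold higher number from compound 1 to compound 3 (0.86 log units; beyond the scatter) and lies beyond the scatter. The group at this position therefore matters for growth inhibition on the core of compound 1. Nothing at hand gives a reason for this step. On these data alone, whether the step is specific to amino remains open, since a methylamino, a methoxy or a hydrogen at this carbon would show how other groups compare with chloro. Whether the same change behaves alike with the chloromethyl group placed elsewhere on the benzyl ring also stays unresolved.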